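The source may report more compounds than this note shows. Statements on the series, on what has been measured and on what is new or still open speak of the compounds shown alone.

Compound 1 `O=C(NCCNc1nccc(-c2c(-c3cccc(F)c3)nc3sccn23)n1)c1c(F)cccc1F`: 11400 nM
Compound 2 `O=S(=O)(NCCCNc1nccc(-c2c(-c3cccc(F)c3)nc3sccn23)n1)c1ccc(Cl)cc1`: 8450 nM

Measured in a functional assay on SK-MEL-28 cells (Homo sapiens) for cytotoxicity, read by MTT assay (on this read-out higher numbers stand for weaker inhibition and lower numbers for stronger inhibition), the two compounds cannot be told apart on this read-out: the step between them, a 1.3-fold lower number from compound 1 to compound 2 (0.13 log units; within the scatter), lies within the scatter. Compound 3 `O=S(=O)(NCCNc1nccc(-c2c(-c3cccc(F)c3)nc3sccn23)n1)c1cccc(F)c1` differs from compound 2 in one place: ((3-fluorophenyl)sulfonyl)amino in place of (((4-chlorophenyl)sulfonyl)amino)methyl on a saturated chain carbon, two bonds along the chain from a nitrogen on an aromatic ring. The chain thus returns to the length it has in compound 1 while keeping a sulfonyl-bearing group at its end, now carrying a 3-fluorophenyl ring instead of a 4-chlorophenyl ring. Among the compounds with values here, the only measured step that bears on this region, a 1.3-fold lower number from compound 1 to compound 2 (0.13 log units; within the scatter), exchanged an amide-bearing chain for a sulfonyl-bearing one and moved nothing beyond the scatter. On that basis no step beyond the scatter in this assay is expected here either. Compound 3 is therefore estimated at 10000 nM, with a range from 4000 nM to 25000 nM, an expected step of a 1.2-fold higher number from compound 2 to compound 3 (0.07 log units; within the scatter).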

Compound 3, half-maximal inhibitory concentration: 18300 nM
Compound 3: middle estimate off by 1.8-fold (0.26 log units), on the low side; the measured number falls inside the stated range.
By their numbers in this assay, from the lowest: compounds 2, 1 and 3 (each within the scatter of the next, the first and the last beyond it).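

In this assay, within the data shown here, the step of a 2.2-fold higher number from compound 2 to compound 3 (0.34 log units; beyond the scatter) is the first change in this small set to pass the usual scatter, though only modestly. It replaces (((4-chlorophenyl)sulfonyl)amino)methyl with ((3-fluorophenyl)sulfonyl)amino, so the chain length and the ring substituent change together and their contributions cannot be separated. With the chain kept as in compound 1, placing (3-fluorophenyl)sulfonyl where (2,6-difluorophenyl)carbonyl stood on the amine nitrogen gives a 1.6-fold higher number from compound 1 to compound 3 (0.21 log units; within the scatter) and so does not distinguish the two groups on this read-out.

Still open, from the compounds shown here alone, is how the 4-chlorophenyl ring would behave on the chain of compound 3, and how a longer chain or a simple amine at the chain end would compare. Nothing available explains why compound 2 and compound 3 differ.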